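Swapping an Oxazole for a Primary Amide on the Side Chain

The source may report more compounds than this note shows. Statements on the series, on what has been measured and on what is new or still open speak of the compounds shown alone.

Compound 1 `CC(C)C(Nc1nnc[nH]1)c1ccc(-c2ccc3cccc(F)c3c2)[nH]c1=O` in an ADME assay on microsomes from liver (Homo sapiens) for metabolic stability (on this read-out lower numbers stand for a shorter-lived compound and higher numbers for a longer-lived compound), gives > 3 h, which is a limit of the assay, not a number.
Compound 2 `CC(C)C(c1ncco1)c1ccc(-c2ccc3cccc(F)c3c2)[nH]c1=O` in this assay gives 0.178 h.
Compound 3 `CC(C)C(Cc1nnn[nH]1)c1ccc(-c2ccc3cccc(F)c3c2)[nH]c1=O` in this assay gives > 3 h, again a limit of the assay.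

Compound 2 thus holds the only actual number shown; the other two values are limits. Compound 4 `CC(C)C(CC(N)=O)c1ccc(-c2ccc3cccc(F)c3c2)[nH]c1=O` differs from compound 2 at one place: carbamoylmethyl in place of 1,3-oxazol-2-yl on a saturated chain carbon bound to an aromatic carbon and a saturated chain carbon. Within the data shown here, two measured steps bear on this change, both at the same place on the chain carbon: an at least 16-fold lower number from compound 1 to compound 2 (1.22 log units; beyond the scatter) and an at least 16-fold higher number from compound 2 to compound 3 (1.22 log units; beyond the scatter). Either way, leaving the 1,3-oxazol-2-yl behind, or arriving at it, moved the value to or from the limit of > 3 h in this assay, at which 2 of the 3 values shown sit. A large rise in this assay is therefore expected for compound 4. Compound 4 is estimated at 2.5 h, within 0.8 h to 6 h. The expected step is a 14-fold higher number from compound 2 to compound 4 (1.15 log units; beyond the scatter).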

Compound 4, half-life: < 0.0667 h
Compound 4 was reported as a limit (the forecaster's own chance of this, stated with the estimate: 50%); at least 37-fold (1.57 log units) between middle value and limit.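

Leaving the 1,3-oxazol-2-yl does not by itself raise the half-life at this position in this assay: carbamoylmethyl gives an at least 2.6-fold lower number from compound 2 to compound 4 (0.42 log units; beyond the scatter). The other two comparisons are an at least 44-fold lower number from compound 3 to compound 4 (1.65 log units; beyond the scatter) and an at least 44-fold lower number from compound 1 to compound 4 (1.65 log units; beyond the scatter), so the outcome depends on which group enters, not merely on the oxazole leaving. Compound 4 sits at a limit of the assay, at the short-lived end: the limit of < 0.0667 h in this assay, at which 1 of the 4 values shown sits.

How far compound 4 lies past that limit cannot be read. On these data alone, whether a carboxylic acid or a primary amine on this chain carbon would behave like the carbamoylmethyl or the (1H-tetrazol-5-yl)methyl remains open.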